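This account rests on a few compounds, and the source may have more. Where it says the series, first, only, none or still open, it means among the compounds named here.

Compound 1 `ClCc1ccccc1Cn1cnc2c(Cl)nc(Cl)nc21` and compound 2 `ClCc1cccc(Cn2cnc3c(Cl)nc(Cl)nc32)c1` contain the same atoms joined differently; the difference between the two cores is not broken down here. In a functional assay on EKVX cells (Homo sapiens) for cytotoxicity, read by sulforhodamine B assay, with a stated time of 48 h (a lower number here means a stronger inhibitor of growth, a higher number a weaker inhibitor of growth), compound 1 gives 3230 nM, and compound 2 gives 2310 nM, the two numbers lying within the usual scatter of each other. Compound 3 `Nc1nc(Cl)c2ncn(Cc3ccccc3CCl)c2n1` differs from compound 1 by a single change, (amino in place of chloro on an aromatic carbon). In this assay compound 3 gives 30900 nM, a step of a 9.6-fold higher number from compound 1 to compound 3 (0.98 log units; beyond the scatter). Compound 4 `Nc1nc(Cl)c2ncn(Cc3cccc(CCl)c3)c2n1` stands to compound 2 as compound 3 stands to compound 1: the change is amino in place of chloro on an aromatic carbon, the same change at the same place, made twice in all among these compounds. Within the data shown here, the corresponding step is expected to be of similar size, a 9.5-fold higher number from compound 2 to compound 4 (0.98 log units; beyond the scatter), an expectation resting on the single earlier step of a 9.6-fold higher number from compound 1 to compound 3 (0.98 log units; beyond the scatter) and on compound 2 giving 2310 nM, a number within the scatter of compound 1. Compound 4 is accordingly estimated at 22000 nM in this assay, with a range from 8000 nM to 60000 nM. One prior instance is a thin basis, and the next measurement settles it.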

Compound 4, concentration for total growth inhibition: 36300 nM
Beside the measured number, compound 4's estimate is 1.7-fold (0.22 log units) below it; the range from low to high includes it.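

In this assay, amino in place of chloro on the core of compound 2 gives a 16-fold higher number from compound 2 to compound 4 (1.20 log units; beyond the scatter). Set beside the earlier step on the core of compound 1, the change carries over between the two cores with no difference that can be told apart: the same change on two cores in this assay, a 9.6-fold higher number (0.98 log units; beyond the scatter) from compound 1 to compound 3 and a 16-fold higher number (1.20 log units; beyond the scatter) from compound 2 to compound 4, 1.6-fold (0.22 log units) apart, within the scatter of two such steps This rests on two cores, one cell line and one read-out, so it supports carrying the change between these two cores only; it does not show that the step would hold on any other core, and it does not explain why the number rises.

Open, going by these compounds, is whether another group on this aromatic carbon between two ring nitrogen atoms, such as a methoxy group, a methylamino group or a longer chain, would give a number closer to those of the chloro compounds. On these data alone, the chloro group meta to this carbon is present in all four compounds, and what an amine or a methoxy group would do in its place is also open.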